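The compounds below may be only part of what the source reports. "The series", "measured", "known", "first", "only" and "open" are said of these compounds alone.

Measured so far:
compound 1 `O=C(NCc1ccc(S(=O)(=O)c2ccccc2)cc1)N1Cc2ccncc2C1`: 115000 nM
compound 2 `CC(=O)N1CCC(S(=O)(=O)c2ccc(CNC(=O)N3Cc4ccncc4C3)cc2)CC1`: 187000 nM

Both numbers come from a physicochemical assay for solubility, in phosphate buffer, with a stated time of 24 h, at pH 7.4, tested at 100 uM; on this read-out lower numbers stand for lower solubility and higher numbers for higher solubility. Compound 2 stands level with compound 1, and their two numbers lie within the usual scatter of each other. Compound 3 `O=C(NCc1ccc(S(=O)(=O)N2CCC(O)CC2)cc1)N1Cc2ccncc2C1` has not been measured yet. It differs from compound 2 by having 4-hydroxypiperidin-1-yl in place of 1-acetylpiperidin-4-yl on a sulfonyl sulfur.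

Among the compounds with values here, only one measured step bears on this change, and only indirectly. Putting 1-acetylpiperidin-4-yl in place of phenyl on a sulfonyl sulfur gave a 1.6-fold higher number from compound 1 to compound 2 (0.21 log units; within the scatter). Within the data shown here, the one exchange tried at this place therefore left the read-out in this assay within the scatter. A single step of that size points in no direction, so no change beyond the scatter is expected here. The estimated step is a 1.2-fold lower number from compound 2 to compound 3 (0.07 log units; within the scatter). For compound 3, the expected value is about 160000 nM, with an estimated range of 80000 nM to 300000 nM.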

Compound 3, solubility: 174000 nM
The estimate for compound 3 lay 1.1-fold (0.04 log units) below the measured number; the range from low to high includes it.
By their numbers in this assay, from the lowest: compounds 1, 3 and 2 (each within the scatter of the next).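

In this assay, 4-hydroxypiperidin-1-yl in place of 1-acetylpiperidin-4-yl on the sulfonyl sulfur gave a 1.1-fold lower number from compound 2 to compound 3 (0.03 log units; within the scatter) and so stayed within the scatter, even though a group with no hydrogen-bond donor gave way to one that has a hydrogen-bond donor. Within the data shown here, measured against the phenyl group of the first compound, the same group gave a 1.5-fold higher number from compound 1 to compound 3 (0.18 log units; within the scatter) and that too lies within the scatter, so phenyl, 1-acetylpiperidin-4-yl and 4-hydroxypiperidin-1-yl now stand level in this read-out, the first time three different groups at this place can be compared with one another. No independent measurement here offers an explanation for this result.

On these data alone, whether a carboxylic acid or a primary amine on the piperidine ring, or a plain alkyl chain on the sulfonyl sulfur, would move the number beyond the scatter remains open. As far as these compounds go, all three compounds also share the same core, so it stays unknown whether groups at this place would stand as level on a different core.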